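Swapping the Aryl Group on the Sulfonyl Sulfur

The compounds below may be only part of what the source reports. "The series", "measured", "known", "first", "only" and "open" are said of these compounds alone.

In an assay on isolated protein for displacement of a labelled ligand from metabotropic glutamate receptor 5 (Homo sapiens), with a stated time of 60 min, tested at 1 uM (a higher number here means more inhibition at the concentration tested (going by the name of the read-out), a lower number less inhibition), compound 1 `Cc1ccc(S(=O)(=O)c2cnc3cc(F)ccc3c2N2CCC(C)CC2)cc1C` gives 90%. Compound 2 `CC1CCN(c2c(S(=O)(=O)c3ccc(Cl)cc3)cnc3cc(Cl)ccc23)CC1` gives 91% in this assay, and the two numbers lie within the scatter of each other, so neither compound stands apart. Compound 3 `Cc1ccc(S(=O)(=O)c2cnc3cc(Cl)ccc3c2N2CCC(C)CC2)cc1C` carries 3,4-dimethylphenyl in place of 4-chlorophenyl on a sulfonyl sulfur. Compound 1 already bears 3,4-dimethylphenyl on its sulfonyl sulfur and gives 90%, so no step beyond the scatter is expected here. The expected step is a number 1 percentage points lower from compound 2 to compound 3 (within the scatter), in no clear direction. Compound 3 is accordingly estimated at 90%, with a range from 78% to 97%.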

Compound 3, a percentage reported as inhibition, at one concentration (the size of the read-out at that concentration, not a potency): 86%
Compound 3: the middle estimate sits 4 percentage points above what was measured, within the range that was stated.
By their numbers in this assay, from the lowest: compounds 3, 1 and 2 (each within the scatter of the next).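

With the rest of the molecule held, 3,4-dimethylphenyl in place of 4-chlorophenyl on the sulfonyl sulfur gives a number 5 percentage points lower from compound 2 to compound 3 (within the scatter) in this assay, so this position accepts either aryl group in this read-out. The second single change now available, chloro in place of fluoro on an aromatic carbon, gives a number 4 percentage points lower from compound 1 to compound 3 (within the scatter) and likewise separates nothing. No measurement at hand bears on these results. On these data alone, it remains open whether an aryl group is needed on the sulfonyl sulfur at all, and how a pyridyl ring or a methyl group would read there. A read-out at one concentration also leaves the potencies of these compounds unresolved.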